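This account rests on a few compounds, and the source may have more. Where it says the series, first, only, none or still open, it means among the compounds named here.

Working notes on the series. Compound 1, `OC[C@@]1(c2ccc(O)cc2)NC[C@@H](O)[C@@H]1O`, was tested in an assay on isolated protein for inhibition of tissue alpha-L-fucosidase (Bos taurus), tested at 1000 uM (a higher number here means more inhibition at the concentration tested (going by the name of the read-out), a lower number less inhibition), where compound 1 gives 0%. Compound 2, `Cc1ccc([C@@]2(CO)NC[C@H](O)[C@H]2O)cc1`, gives 3.3% in this assay. Compound 1 stands at the lowest of the two numbers, but the two values lie within the scatter of each other, so neither compound is separated from the other on these data. Compound 3, `OC[C@@]1(c2ccc(F)cc2)NC[C@@H](O)[C@@H]1O`, has not been measured in this assay. It differs from compound 1 in one place: fluoro in place of hydroxy on an aromatic carbon. Going by the values given here, no step between measured compounds bears on this change. Both measured compounds sit near zero inhibition at the concentration tested, and nothing in the numbers shown points to a move beyond the scatter in either direction. The expected step is a number 3 percentage points higher from compound 1 to compound 3 (within the scatter), that is, none beyond the scatter. For compound 3 in this assay an inhibition of 3% is estimated, within a range from 0% to 15%.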

Compound 3, a percentage reported as inhibition, at one concentration (the size of the read-out at that concentration, not a potency): 0%
Compound 3: the middle estimate sits 3 percentage points above what was measured; low and high end bracket the measured number.
By their numbers in this assay, from the lowest: compounds 1, 3 and 2 (each within the scatter of the next).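

Read in this assay, fluoro in place of hydroxy on an aromatic carbon gives no change at the digits printed from compound 1 to compound 3 (within the scatter), the first step in the series that can be read at this position. The change takes away the hydrogen-bond donor and the hydrogen-bond acceptor counted for hydroxy, yet no difference beyond the scatter comes with it, although with compound 1 at 0% a further fall could not show on this read-out. No measurement on hand bears on the reason for this result.

As far as these compounds go, whether an amine, a carboxylic acid or a longer chain at this position would move the read-out beyond the scatter remains open. Equally open, from the compounds shown here alone, is whether the core of compound 1 can give measurable inhibition in this assay with any group at this position.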